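This account rests on a few compounds, and the source may have more. Where it says the series, first, only, none or still open, it means among the compounds named here.

Compound 1 `C[C@@H](O)[C@H]1C(=O)N2C(C(=O)OCOC(=O)C(C)(C)C)=C(S[C@@H]3CN[C@H](C(=O)Nc4cccc(C(=O)O)c4)C3)[C@H](C)[C@H]12` is one of three closely related compounds examined in an ADME assay for metabolic stability, read by LC-MS, with a stated time of 3 h, at pH 6.5, tested at 50 uM; a higher number here means that more of the compound is left, a lower number that less of the compound is left. In this assay compound 1 gives > 95%, which is a limit of the assay rather than a number. Compound 2 `CCOC(=O)C1=C(S[C@@H]2CN[C@H](C(=O)Nc3cccc(C(=O)O)c3)C2)[C@H](C)[C@@H]2[C@@H]([C@@H](C)O)C(=O)N12` gives > 95% in this assay, also a limit. Compound 3 `CC(C)OC(=O)OCOC(=O)C1=C(S[C@@H]2CN[C@H](C(=O)Nc3cccc(C(=O)O)c3)C2)[C@H](C)[C@@H]2[C@@H]([C@@H](C)O)C(=O)N12` likewise gives > 95%, again a limit. Because (the limit of > 95% in this assay, at which 3 of the 3 values shown sit), the steps a step that the two limits leave unreadable from compound 1 to compound 2, a step that the two limits leave unreadable from compound 1 to compound 3 and a step that the two limits leave unreadable from compound 2 to compound 3 cannot be read in size or direction. Compound 4 `C[C@@H](O)[C@H]1C(=O)N2C(C(=O)OCOC(=O)C(C)(C)C)=C(S[C@@H]3CN[C@H](C(=O)Nc4cccc(C(=O)OCOC(=O)C(C)(C)C)c4)C3)[C@H](C)[C@H]12` differs from compound 1 by (((tert-butyl)carbonyl)oxy)methyl in place of hydrogen on an oxygen next to a carbonyl group. Among the compounds with values here, since none of the measured steps has a readable size, no change beyond the scatter is expected. Compound 4 is therefore expected to give 96% in this assay, between 88% and 100%. This implies an estimated step that the limit leaves unreadable from compound 1 to compound 4.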

Compound 4, percent of the compound remaining: > 95%
Compound 4 gave a limit, no number (the forecaster's own chance of this, stated with the estimate: 75%); the middle value does not contradict the limit.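

The step between compound 1 and compound 4 cannot be read in size or direction, because both sit at the same limit: the limit of > 95% in this assay, at which 4 of the 4 values shown sit.

The compounds shown leave open whether any of these changes of group affects how much compound is left in this assay.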